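Ester side-chain variation on the dihydropyridine series

The source may hold more compounds than are shown below. What is called first, only, known or untested is meant among the compounds shown, and "the series" means these compounds.

Two compounds of this series have numbers in a functional assay on HEK293 cells for antagonist activity at Voltage-dependent L-type calcium channel subunit alpha-1D (Rattus norvegicus), read by FLIPR; a lower number here means a stronger inhibitor, a higher number a weaker inhibitor. Compound 1 `CCOC(=O)C1=C(C)NC(C(OCC)OCC)=C(C(=O)OCC)C1c1cccc([N+](=O)[O-])c1` carries ethyl esters on both sides and a diethoxymethyl group on the core; in this assay compound 1 gives 615 nM. Compound 2 `COC(=O)C1=C(C)NC(C)=C(C(=O)OCCCl)C1c1cccc([N+](=O)[O-])c1` carries a methyl ester on one side and a 2-chloroethyl ester on the other; in this assay compound 2 gives 22 nM. Compound 2 thus stands at the lowest of the two numbers, and the gap to compound 1 lies beyond the scatter of repeated measurements.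

Compound 3 `COC(=O)C1=C(C)NC(C)=C(C(=O)OCCC(C)c2ccccc2)C1c1cccc([N+](=O)[O-])c1` is not yet measured. It differs from compound 2 in one place: 1-phenylethyl in place of chloro on a saturated chain carbon, two bonds along the chain from an oxygen next to a carbonyl group. For the measured compounds named here, no step between two measured compounds of this kind is available, so the size of the change can only be expected, not read off. The working expectation is that the number stays close to that of compound 2, with a slight shift toward a stronger inhibitor not excluded. The step from compound 2 to compound 3 is therefore estimated at a 1.5-fold lower number from compound 2 to compound 3 (0.17 log units; within the scatter). For compound 3 in this assay the estimate is 15 nM, with a range from 4 nM to 60 nM.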

Compound 3, half-maximal inhibitory concentration: 11 nM
Beside the measured number, compound 3's estimate is 1.4-fold (0.13 log units) above it; the range from low to high includes it.
By their numbers in this assay, from the lowest: compounds 3 and 2 (each within the scatter of the next); then compound 1.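

In this assay, the exchange of chloro for 1-phenylethyl on a saturated chain carbon, two bonds along the chain from an oxygen next to a carbonyl group, comes to a 2.0-fold lower number from compound 2 to compound 3 (0.30 log units; within the scatter), so the numbers of these two compounds cannot be told apart. For the compounds shown here, this place in the ester side chain therefore accepts 8 heavy atoms with a six-membered aromatic ring of carbon only where compound 2 has 1 chlorine atom, and the number stays in the same range; the earlier compounds, which differ in more than one place, could not show this. Nothing at hand bears on why the number holds across so large a difference in the group.

Open, as far as these compounds go, is whether an amine or a carboxylic acid at this place on the chain, or a phenyl group on a straight chain without the branching methyl, would keep the number in this range. Compound 1 differs from compound 2 and compound 3 in more than one place, so the share of its diethoxymethyl group and that of its ethyl esters in its higher number cannot be read apart.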